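Swapping the cyclohexyl for 4-fluorophenyl

The compounds below may be only part of what the source reports. "The series", "measured", "known", "first", "only" and "open" are said of these compounds alone.

Compound 1: `CN1CCC[C@@H]1Cn1nc(Cc2ccc(O)cc2)c2ccccc2c1=O`, 251 nM in an assay for binding affinity to Alpha-1A adrenergic receptor (Homo sapiens); on this read-out higher numbers stand for weaker inhibition and lower numbers for stronger inhibition.
Compound 2: `CN1CCC[C@@H]1Cn1nc(CC2CCCCC2)c2ccccc2c1=O`, > 1990 nM in this assay, which is a limit of the assay and not a number.
Compound 3: `O=c1c2ccccc2c(Cc2ccc(Cl)cc2)nn1C[C@H]1CCCN1CCCCCc1ccc(OCCCN2CCCCCC2)cc1`, 25.1 nM in this assay.

Compound 2 therefore stands at the weak end of the measured set, known only as a limit (the limit of > 1990 nM in this assay, at which 1 of the 3 values shown sits). The unmeasured compound 4, `CN1CCC[C@@H]1Cn1nc(Cc2ccc(F)cc2)c2ccccc2c1=O`, differs from compound 2 by 4-fluorophenyl in place of cyclohexyl on a saturated chain carbon bound to an aromatic carbon. Among the measured compounds shown here, one measured step bears on this change: an at least 7.9-fold higher number from compound 1 to compound 2 (0.89 log units; beyond the scatter). Compound 4 reverses that move back to an aromatic ring, though with a fluorine where compound 1 carries a hydroxyl, so a sizeable return toward stronger binding is expected in this assay, yet the fluorinated ring is not expected to recover all of the distance to compound 1. For compound 4 the expected step is an at least 4.9-fold lower number from compound 2 to compound 4 (0.69 log units; beyond the scatter). Compound 4 is thus estimated at 400 nM, within a range from 100 nM to 2000 nM.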

Compound 4, inhibition constant: 63.1 nM
Estimate against measurement, compound 4: 6.3-fold (0.80 log units) above; measured number below the stated range.
By their numbers in this assay, from the lowest: compound 3; then compound 4; then compound 1. At a limit, above all of these: compound 2.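

In this assay compound 2 is known only as a limit of the assay and not as a number: the limit of > 1990 nM in this assay, at which 1 of the 4 values shown sits. Against that limit, the return to an aromatic ring gives an at least 31-fold lower number from compound 2 to compound 4 (1.49 log units; beyond the scatter), so recovery from the cyclohexyl compound does not depend on the hydroxy group of compound 1. Fluoro in place of hydroxy on an aromatic carbon goes further, with a 4.0-fold lower number from compound 1 to compound 4 (0.60 log units; beyond the scatter), which shows that the group on the ring also moves the number and that a hydroxy group is not required for binding at this position.

The compounds shown leave open how an unsubstituted phenyl, a 4-chlorophenyl or a 4-methoxyphenyl would compare here, and so whether the gain is specific to fluoro. They also leave open how 4-fluorophenyl would read alongside the longer chain that compound 3 carries.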